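The source may report more compounds than this note shows. Statements on the series, on what has been measured and on what is new or still open speak of the compounds shown alone.

Values in a physicochemical assay for lipophilicity, measured as octanol-water partition; a higher number here means a more lipophilic compound, a lower number a more polar compound:
- compound 1 `O=C(NNc1ccnc2cc(Cl)ccc12)c1ccccc1/N=C/c1ccc(Cl)cc1Cl` gives 6.22 
- compound 2 `CN(C)c1ccc(/C=N/c2ccccc2C(=O)NNc2ccnc3cc(Cl)ccc23)cc1` gives 5.03 
- compound 3 `O=C(NNc1ccnc2cc(Cl)ccc12)c1ccccc1/N=C/c1cccs1` gives 4.78 

Compound 3 stands clear of compound 1 on the low side (a number 1.44 log units lower from compound 1 to compound 3 (beyond the scatter)) and level with compound 2 (a number 0.25 log units lower from compound 2 to compound 3 (within the scatter)). The next compound, compound 4 (`O=C(NNc1ccnc2cc(Cl)ccc12)c1ccccc1/N=C/c1ccncc1`), differs from compound 3 at the same place (pyridin-4-yl in place of thiophen-2-yl on a carbon with a double bond to nitrogen): pyridin-4-yl in place of thiophen-2-yl on a carbon with a double bond to nitrogen.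

All three measured steps fall at this place. Leaving 2,4-dichlorophenyl gave large moves (a number 1.19 log units lower from compound 1 to compound 2 (beyond the scatter)), while the exchange between the other two groups gave none beyond the scatter. For the measured compounds named here, no measured compound carries pyridin-4-yl, so these steps bound the size only loosely, and the direction is a judgement from a ring with nitrogen entering for a ring with sulfur. A moderate drop is expected (a number 0.68 log units lower from compound 3 to compound 4 (beyond the scatter)), smaller than the step from 2,4-dichlorophenyl. Compound 4 is therefore estimated at 4.1 (expected range 3.6 to 4.6).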

Compound 4, partition coefficient: 3.86
Compound 4: middle estimate off by 0.24 log units, on the high side; low and high end bracket the measured number.
By their numbers in this assay, from the lowest: compound 4; then compounds 3 and 2 (each within the scatter of the next); then compound 1.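

Among the groups other than 2,4-dichlorophenyl, this position now shows a change beyond the scatter in this assay: the exchange of thiophen-2-yl and 4-(dimethylamino)phenyl had moved the number by no more than the scatter, yet pyridin-4-yl separates from both (a number 0.92 log units lower from compound 3 to compound 4 (beyond the scatter); a number 1.17 log units lower from compound 2 to compound 4 (beyond the scatter)). The range reached at this single place also widens (a number 2.36 log units lower from compound 1 to compound 4 (beyond the scatter)), and compound 4 is the lowest of the four, with its steps to all the others beyond the scatter. No measurement shown here accounts for these steps.

Where unsubstituted phenyl, pyridin-3-yl or a phenyl ring carrying a carboxylic acid would fall relative to compound 4 remains open. So does whether the order of these groups would hold with a different group elsewhere on the shared core.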